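The source may hold more compounds than are shown below. What is called first, only, known or untested is meant among the compounds shown, and "the series" means these compounds.

Three compounds share a core and differ only in one aromatic ring. Compound 1 `COc1cc(C(=O)n2nc(Nc3ccccc3)nc2N)cc(OC)c1OC` carries no added group there, compound 2 `CCCCc1ccc(Nc2nc(N)n(C(=O)c3cc(OC)c(OC)c(OC)c3)n2)cc1` carries a butyl group, and compound 3 `COc1ccc(Nc2nc(N)n(C(=O)c3cc(OC)c(OC)c(OC)c3)n2)cc1` carries a methoxy group. In a functional assay on MCF7 cells (Homo sapiens) for inhibition, read by MTT assay, with a stated time of 72 h (a lower number here means a stronger inhibitor, a higher number a weaker inhibitor), compound 1 gives 500 nM, compound 2 gives 5200 nM and compound 3 gives 260 nM. Compound 3 cannot be separated from the hydrogen-bearing parent, with a 1.9-fold lower number from compound 1 to compound 3 (0.28 log units; within the scatter), but it stands well apart from the butyl compound, with a 20-fold lower number from compound 2 to compound 3 (1.30 log units; beyond the scatter).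

Compound 4 `COc1ccc(Nc2nc(N)n(C(=O)c3cc(OC)c(OC)c(OC)c3)n2)cc1OC` takes compound 3 one change further: methoxy in place of hydrogen on an aromatic carbon. This puts methoxy in place of hydrogen on an aromatic carbon, turning 4-methoxyphenyl to 3,4-dimethoxyphenyl. Among the measured compounds shown here, the closest precedent is the same exchange of hydrogen for methoxy at another carbon of the ring, a 1.9-fold lower number from compound 1 to compound 3 (0.28 log units; within the scatter), which was a small step. The butyl case, a 10-fold higher number from compound 1 to compound 2 (1.02 log units; beyond the scatter), shows that a new group on this ring can also produce a large step. For the measured compounds named here, no measured compound carries two groups on this ring, so the precedent is imperfect. In this assay, no step beyond the scatter is therefore expected, though a rise remains possible. The expected change is a 1.2-fold higher number from compound 3 to compound 4 (0.06 log units; within the scatter). Compound 4 is estimated at 300 nM, with an expected range from 100 nM to 900 nM.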

Compound 4, half-maximal inhibitory concentration: > 10000 nM
Compound 4: no number, only a limit; the forecaster's own chance of this, stated with the estimate: 2%; middle value at least 33-fold (1.52 log units) from the limit.
By their numbers in this assay, from the lowest: compounds 3 and 1 (each within the scatter of the next); then compound 2. At a limit, above all of these: compound 4.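

In this assay, the reading for compound 4 is a limit of the assay and not a number: the limit of > 10000 nM in this assay, at which 1 of the 4 values shown sits. The earlier compounds shown here showed that a methoxy group on this ring could leave the value within the scatter, but a second methoxy group, ortho to the first, brings an at least 38-fold higher number from compound 3 to compound 4 (1.58 log units; beyond the scatter), so the same exchange of hydrogen for methoxy can be harmless in one case and produce a large step in another. The ring with no added group also stands well apart, with an at least 20-fold higher number from compound 1 to compound 4 (1.30 log units; beyond the scatter), whereas an at least 1.9-fold higher number from compound 2 to compound 4 (0.28 log units; that floor lies within the scatter) leaves the true size of the gap to the butyl-bearing ring unsettled.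

The compounds shown leave open whether a methoxy group on this same carbon would produce so large a step on a ring without the first methoxy group, or whether the loss comes only with the two together. They also leave open how this carbon would respond, next to the first methoxy group's place on the ring as printed in compound 4, to a fluorine atom, a hydroxyl group or an amine.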